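Morpholine to Piperazine on the Dithiocarbamate of Compound 3

This account rests on a few compounds, and the source may have more. Where it says the series, first, only, none or still open, it means among the compounds named here.

In a functional assay on SW-620 cells (Homo sapiens) for inhibition, read by MTT assay, with a stated time of 72 h (on this read-out higher numbers stand for weaker inhibition and lower numbers for stronger inhibition), compound 1 `CCCCCCCCc1cn(Cc2cc(=O)oc3cc(O)ccc23)nn1` gives 50900 nM, and compound 2 `O=c1cc(Cn2cc(CCc3ccccc3)nn2)c2ccc(O)cc2o1` gives 84400 nM; the step between them, a 1.7-fold higher number from compound 1 to compound 2 (0.22 log units; within the scatter), does not rise above the scatter. Compound 3 `O=c1cc(Cn2cc(CSC(=S)N3CCOCC3)nn2)c2ccc(O)cc2o1` carries a different group on the saturated chain carbon bound to an aromatic carbon. In this assay compound 3 reaches only the limit of the assay, >= 100000 nM, so its value is a floor rather than a number. The steps into it, an at least 1.9-fold higher number from compound 1 to compound 3 (0.29 log units; that floor lies within the scatter) and an at least 1.1-fold higher number from compound 2 to compound 3 (0.07 log units; that floor lies within the scatter), are floors whose sizes lie within the scatter, and the limit of >= 100000 nM in this assay, at which 1 of the 3 values shown sits, marks where compound 3 sits among the three.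

Compound 4 `O=c1cc(Cn2cc(CSC(=S)N3CCNCC3)nn2)c2ccc(O)cc2o1` differs from compound 3 by piperazin-1-yl in place of morpholin-4-yl on a thiocarbonyl carbon. For the measured compounds named here, none of the measured steps exchanges these two rings on a thiocarbonyl carbon, and the only steps that touch compound 3 are themselves floors within the scatter. The expectation for compound 4 therefore rests on compound 3 alone: compound 4 is estimated to sit close to where compound 3 sits, with a step of a number no higher from compound 3 to compound 4 (the limit leaves the size open) that is expected to fall within the scatter, and compound 4 is expected to give about 100000 nM, plausibly between 40000 nM and 300000 nM.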

Compound 4, half-maximal inhibitory concentration: > 100000 nM
Compound 4: no number, only a limit; the forecaster's own chance of this, stated with the estimate: 55%; the middle value lies on the limit itself.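

In this assay compound 4 reaches only a limit of the assay and not a number: the limit of > 100000 nM in this assay, at which 1 of the 4 values shown sits. Compound 3 also stands at a limit, so piperazin-1-yl in place of morpholin-4-yl on a thiocarbonyl carbon, which brings in the hydrogen-bond donor of the piperazine ring, gives no number at this position, and the step between the two cannot be read. The steps that can be read, an at least 1.1-fold higher number from compound 2 to compound 4 (0.07 log units; that floor lies within the scatter) and an at least 1.9-fold higher number from compound 1 to compound 4 (0.29 log units; that floor lies within the scatter), are floors that do not rise above the scatter, so they do not separate the piperazine compound from the two chain-bearing compounds.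

What the compounds shown leave open is whether any group on this thiocarbonyl carbon brings the read-out under the limit, for instance piperidin-1-yl, with carbon alone beside its ring nitrogen, or 4-methylpiperazin-1-yl, with a methyl on the free ring nitrogen. Also open, from the compounds shown here alone, is how far apart compound 3 and compound 4 really lie, since neither has a value beyond its limit.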